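The source may hold more compounds than are shown below. What is called first, only, known or untested is meant among the compounds shown, and "the series" means these compounds.

In a functional assay on A549 cells (Homo sapiens) for antiproliferative activity, read by MTT assay, with a stated time of 72 h (a higher number here means a weaker inhibitor, a lower number a stronger inhibitor), compound 1 `CC(C)(C)c1ccc(OCCCON2C(N)=NC(N)=NC23CCSCC3)cc1` gives 1 nM and compound 2 `NC1=NC2(CCSCC2)N(OCCCOc2cccc(Cl)c2Cl)C(N)=N1` gives 1 nM as well. Compound 3 `NC1=NC2(CCSCC2)N(OCCCOc2ccccc2Cl)C(N)=N1` gives 80 nM and so holds the highest number of the three, beyond the scatter from both others. Compound 4 `NC1=NC2(CCSCC2)N(OCCCOc2ccc(Cl)cc2)C(N)=N1` has the same atoms as compound 3 joined differently, and the change 4-chlorophenyl in place of 2-chlorophenyl on an oxygen on a saturated carbon puts 4-chlorophenyl in place of 2-chlorophenyl on an oxygen on a saturated carbon. Among the compounds with values here, one measured step bears on this, the large rise an 80-fold higher number from compound 2 to compound 3 (1.90 log units; beyond the scatter) that comes with hydrogen in place of chloro on an aromatic carbon. Within the data shown here, it shows that a single chloro on this ring can matter a great deal, but no measured pair shows a chloro moving. Compound 3 at 80 nM is the outlier of the set, so a fall looks more likely than a further rise. The expected change in this assay is a 5.3-fold lower number from compound 3 to compound 4 (0.73 log units; beyond the scatter) and this estimate is a moderate fall, smaller than the measured step. Compound 4 is expected in this assay at 15 nM with an estimated range from 2 nM to 100 nM around that middle.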

Compound 4, half-maximal inhibitory concentration: 580 nM
The estimate for compound 4 lay 39-fold (1.59 log units) below the measured number; the whole stated range lies below it.
By their numbers in this assay, from the lowest: compounds 1 and 2 (each within the scatter of the next); then compound 3; then compound 4.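

In this assay, moving the single chloro gives a 7.3-fold higher number from compound 3 to compound 4 (0.86 log units; beyond the scatter), so where the chloro sits on this ring matters as well as whether it is present, which the earlier pair could not show. The wider steps, a 580-fold higher number from compound 2 to compound 4 (2.76 log units; beyond the scatter) and a 580-fold higher number from compound 1 to compound 4 (2.76 log units; beyond the scatter), show that 4-chlorophenyl falls far behind both 2,3-dichlorophenyl and the tert-butyl-bearing ring of compound 1, so the group held at that same ring place also counts heavily. No measurement here gives a reason for these differences.

The compounds shown leave open how 3-chlorophenyl would compare, and so whether the low number of compound 2 depends on both of its chloro groups. They also leave open whether a methoxy or a fluoro in place of the chloro of compound 4 would land nearer compound 4 or compound 1.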